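The compounds below may be only part of what the source reports. "The series", "measured", "known", "first", "only" and "open" are said of these compounds alone.

Working notes on the series, read in a functional assay on HL-60 cells (Homo sapiens) for cytotoxicity, read by trypan blue exclusion, with a stated time of 48 h; a higher number here means a weaker inhibitor, a lower number a stronger inhibitor. Compound 1 (`C=C1C(C)=Cc2c(O)c(C)c(CC)c(C)c21`) gives 140000 nM, compound 2 (`C=C1C(C)=Cc2c(O)c(C)c(CCOC(C)=O)c(C)c21`) gives 110000 nM, and compound 3 (`CC1=C(CO)c2c(C)c(CCO)c(C)c(O)c2C1`) gives 120000 nM. Compound 3 lies within the scatter of both other compounds, so the three values form a single level.

Compound 4 (`CC1=C(CO)c2c(C)c(CCO)c(C)c(O)c2C1O`) differs from compound 3 by hydroxy in place of hydrogen on a saturated ring carbon of the five-membered non-aromatic ring. Among the compounds with values here, the only measured step is a 1.3-fold lower number from compound 1 to compound 2 (0.10 log units; within the scatter), which concerns a saturated chain carbon and bears on this change only loosely. Within the data shown here, no measured step covers a change on this ring carbon, so the basis for the expectation is thin. With that single step inside the scatter and all three values at one level, no step beyond the scatter is expected in this assay. The estimate corresponds to a 1.2-fold lower number from compound 3 to compound 4 (0.08 log units; within the scatter), an expected step within the scatter. Compound 4 is estimated at 100000 nM, with an expected range from 40000 nM to 200000 nM.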

Compound 4, half-maximal inhibitory concentration: 114000 nM
The estimate for compound 4 lay 1.1-fold (0.06 log units) below the measured number, and the stated range covers the measured number.
By their numbers in this assay, from the lowest: compounds 2, 4, 3 and 1 (each within the scatter of the next).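

In this assay, within the data shown here, hydroxy in place of hydrogen on a saturated ring carbon gives a 1.1-fold lower number from compound 3 to compound 4 (0.02 log units; within the scatter) and thus supplies the first measured step at this position of the five-membered non-aromatic ring. This step lies within the scatter, so compound 4 stays at the single level already held by compound 1, compound 2 and compound 3. The chain change in a 1.3-fold lower number from compound 1 to compound 2 (0.10 log units; within the scatter) also lies within the scatter, so neither of the two readable steps, one on the ring and one on the chain, separates compounds in this series. No available evidence gives a reason for this result.

From the compounds shown here alone, whether an amine or a carboxylic acid on this ring carbon would give a step beyond the scatter stays open. Going by these compounds, it also stays open whether any change on the shared core moves the number away from this level.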